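Acetylation of the Remaining Free Hydroxyl Group

This account rests on a few compounds, and the source may have more. Where it says the series, first, only, none or still open, it means among the compounds named here.

Three compounds of a shared core have been characterized in a functional assay on Col2 cells (Homo sapiens) for cytotoxicity, read by sulforhodamine B assay; on this read-out lower numbers stand for an effect already at smaller amounts and higher numbers for an effect only at larger amounts of compound. Compound 1 `C=C1CC[C@@H]2[C@](C)(CO[Si](C)(C)C(C)(C)C)[C@H](O)CC[C@@]2(C)[C@@H]1C/C=C1/C(=O)OC[C@H]1OC(C)=O` gives 8.94 uM. Compound 2 `C=C1CC[C@@H]2[C@](C)(CO[Si](C(C)C)(C(C)C)C(C)C)[C@H](O)CC[C@@]2(C)[C@@H]1C/C=C1/C(=O)OC[C@H]1O` gives 2.73 uM. Compound 3 `C=C1CC[C@@H]2[C@](C)(COC(C)=O)[C@H](O)CC[C@@]2(C)[C@@H]1C/C=C1/C(=O)OC[C@H]1O` gives 12.9 uM, the highest of the three numbers, within the scatter of compound 1 and beyond the scatter of compound 2.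

Going by the values given here, the only single-point step among them is a 4.7-fold higher number from compound 2 to compound 3 (0.67 log units; beyond the scatter). Compound 4 `C=C1CC[C@@H]2[C@](C)(COC(C)=O)[C@H](O)CC[C@@]2(C)[C@@H]1C/C=C1/C(=O)OC[C@H]1OC(C)=O` arises from compound 3 by a different change: acetyl in place of hydrogen on an oxygen on a saturated carbon, which, cut one bond further out, reads hydroxy to acetoxy. Among the compounds with values here, no measured pair isolates this change; compounds 1 and 2 differ at two places, and their values show only that the acetoxy-bearing compound 1 sits higher than the hydroxy-bearing compound 2. Within the data shown here, with no clean precedent, the step is expected to stay near or slightly above compound 3, as a 1.2-fold higher number from compound 3 to compound 4 (0.09 log units; within the scatter). Compound 4 is therefore estimated at 16 uM, within a range of 6 uM to 45 uM.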

Compound 4, concentration for half-maximal effect: 15.2 uM
Estimate against measurement, compound 4: 1.1-fold (0.02 log units) above; the measured number falls inside the stated range.
By their numbers in this assay, from the lowest: compound 2; then compounds 1, 3 and 4 (each within the scatter of the next).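

In this assay, the hydroxy to acetoxy change, on an oxygen on a saturated carbon, gives a 1.2-fold higher number from compound 3 to compound 4 (0.07 log units; within the scatter), so at this position acetyl in place of hydrogen leaves the number unchanged within the scatter. With acetoxy present in both compounds, replacing the silicon-bearing group with acetyl gives a 1.7-fold higher number from compound 1 to compound 4 (0.23 log units; within the scatter), also within the scatter, whereas the earlier step with hydroxy and a different silicon-bearing group, a 4.7-fold higher number from compound 2 to compound 3 (0.67 log units; beyond the scatter), lay beyond it. No measurement bears on why these steps differ in size.

The compounds shown leave open whether a longer acyl chain such as butanoyl, or an amine, at this oxygen would move the number beyond the scatter. They also leave open whether the hydroxy to acetoxy change reads the same in a compound carrying a silicon-bearing group.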